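The compounds below may be only part of what the source reports. "The series", "measured", "known", "first", "only" and "open" are said of these compounds alone.

Working notes on the series in a functional assay on MV cells (Homo sapiens) for inhibition, read by sulforhodamine B assay; on this read-out higher numbers stand for weaker inhibition and lower numbers for stronger inhibition.

Compound 3 `C#CC(=O)N1C(c2ccc(F)cc2)SC[C@@H]1C(=O)OCC` gives 400 nM. On the numbers in hand it stands level with compound 2 `C#CC(=O)N1C(c2ccccc2)SC[C@@H]1C(=O)OCC`, which gives 400 nM, the pair together being the lowest of the three measured; the step of no change at the digits printed from compound 2 to compound 3 (within the scatter) lies within the scatter, so no order between them is claimed. Furthest away stands compound 1 `C#CC(=O)N1C(c2ccc(C#N)cc2)SC[C@@H]1C(=O)OCC`, which gives 2400 nM; the steps of a 6.0-fold lower number from compound 1 to compound 2 (0.78 log units; beyond the scatter) and a 6.0-fold lower number from compound 1 to compound 3 (0.78 log units; beyond the scatter) show that removing the cyano, whether for hydrogen or for fluoro, lowers the number.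

Compound 4 `C#CC(=O)N1C(c2ccc(OC)cc2)SC[C@@H]1C(=O)OCC` is not yet measured. It differs from compound 3 by methoxy in place of fluoro on an aromatic carbon. Among the measured compounds shown here, no measured step exchanges fluoro for methoxy. The nearest comparisons are the cyano-to-fluoro step a 6.0-fold lower number from compound 1 to compound 3 (0.78 log units; beyond the scatter), where a group carrying one hydrogen-bond acceptor gave the higher number, and the hydrogen-to-fluoro step no change at the digits printed from compound 2 to compound 3 (within the scatter), which was flat. On balance a small rise, possibly within the scatter, is expected: a 1.6-fold higher number from compound 3 to compound 4 (0.21 log units; within the scatter). For compound 4 the estimate in this assay is 650 nM, with a range of 250 nM to 1700 nM.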

Compound 4, half-maximal inhibitory concentration: 700 nM
The estimate for compound 4 lay 1.1-fold (0.03 log units) below the measured number, within the range that was stated.
By their numbers in this assay, from the lowest: compounds 2, 3 and 4 (each within the scatter of the next); then compound 1.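

In this assay, the steps of a 1.8-fold higher number from compound 3 to compound 4 (0.24 log units; within the scatter) and a 1.8-fold higher number from compound 2 to compound 4 (0.24 log units; within the scatter) both lie within the scatter, so at this place, para to a large group, methoxy cannot be told apart from fluoro or hydrogen, even though it brings a hydrogen-bond acceptor that they lack. The step of a 3.4-fold lower number from compound 1 to compound 4 (0.54 log units; beyond the scatter) lies beyond the scatter, so compound 1, with its cyano, now stands apart from three compounds rather than two. No measurement is available that gives a cause for this separation.

From the compounds shown here alone, whether cyano is alone in this at this place remains open, since a carboxylic acid, an amine or a nitro group might fall on either side. Also open, going by these compounds, is whether a longer chain such as ethoxy would stay within the scatter of compound 4.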